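The compounds below may be only part of what the source reports. "The series", "measured", "known", "first", "only" and "open" are said of these compounds alone.

In a functional assay on FM3A cells (Mus musculus) for cytotoxicity, read by cell counting, with a stated time of 2 days (on this read-out lower numbers stand for stronger inhibition and higher numbers for weaker inhibition), compound 2 `Nc1cccc(/C=C2\SC(=O)N(Cc3cccc(Cl)c3)C2=O)c1` gives 164000 nM. Compound 1 `Nc1cccc(/C=C2\SC(=O)N(Cc3ccc(F)cc3)C2=O)c1` carries the change (4-fluorophenyl in place of 3-chlorophenyl on a saturated chain carbon bound to an amide-type nitrogen in a ring), and in this assay compound 1 gives 140000 nM; the step is a 1.2-fold lower number from compound 2 to compound 1 (0.07 log units; within the scatter). Compound 3 `C=C(Br)C(=O)Nc1cccc(/C=C2\SC(=O)N(Cc3cccc(Cl)c3)C2=O)c1` differs from compound 2 by (1-bromoethenyl)carbonyl in place of hydrogen on a nitrogen on an aromatic ring, and in this assay compound 3 gives 1700 nM, a step of a 96-fold lower number from compound 2 to compound 3 (1.98 log units; beyond the scatter). Compound 4 `C=C(Br)C(=O)Nc1cccc(/C=C2\SC(=O)N(Cc3ccc(F)cc3)C2=O)c1` differs from compound 3 by 4-fluorophenyl in place of 3-chlorophenyl on a saturated chain carbon bound to an amide-type nitrogen in a ring. The place of this change is described in the same words as for the change from compound 2 to compound 1, so it is the same change, here made on the core of compound 3. The step from compound 3 to compound 4 is expected to be a 1.1-fold lower number from compound 3 to compound 4 (0.05 log units; within the scatter), because the earlier step of a 1.2-fold lower number from compound 2 to compound 1 (0.07 log units; within the scatter) stayed within the scatter. Compound 4 is therefore estimated at 1500 nM, between 600 nM and 4000 nM.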

Compound 4, half-maximal inhibitory concentration: 920 nM
Compound 4: middle estimate off by 1.6-fold (0.21 log units), on the high side; low and high end bracket the measured number.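

In this assay, 4-fluorophenyl in place of 3-chlorophenyl gives a 1.8-fold lower number from compound 3 to compound 4 (0.27 log units; within the scatter), and this step agrees with the same change on the other core: the same change on two cores in this assay, a 1.2-fold lower number (0.07 log units; within the scatter) from compound 2 to compound 1 and a 1.8-fold lower number (0.27 log units; within the scatter) from compound 3 to compound 4, 1.6-fold (0.20 log units) apart, within the scatter of two such steps Adding (1-bromoethenyl)carbonyl to the nitrogen on the aromatic ring gives a 150-fold lower number from compound 1 to compound 4 (2.18 log units; beyond the scatter), and this large step also carries over: the same change on two cores in this assay, a 96-fold lower number (1.98 log units; beyond the scatter) from compound 2 to compound 3 and a 150-fold lower number (2.18 log units; beyond the scatter) from compound 1 to compound 4, 1.6-fold (0.20 log units) apart, within the scatter of two such steps So each change had a similar size on both cores, but two cores are a narrow test, and this neither shows that the same would hold on other cores nor explains why the steps agree.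

The compounds shown leave open whether a plain acetyl group on that nitrogen would give a step of similar size. They also leave open how a longer chain, such as 2-phenylethyl in place of the benzyl group, would behave.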